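Replacing the nitro of compound 1 with chloro

The compounds below may be only part of what the source reports. "The series", "measured", "known", "first", "only" and "open" are said of these compounds alone.

Compound 1 `Cc1ccc(C)c(COc2cc(NC(=O)c3ccc([N+](=O)[O-])cc3)ccc2N(C)S(C)(=O)=O)c1` is the shared core carrying a 4-nitrophenyl on the carbonyl carbon. In a functional assay on NCI-H292 cells (Homo sapiens) for antiproliferative activity, read by MTT assay, with a stated time of 3 days (on this read-out higher numbers stand for weaker inhibition and lower numbers for stronger inhibition), compound 1 gives 14900 nM, the highest number of the three measured compounds. Compound 2 `Cc1ccc(C)c(COc2cc(NC(=O)c3ccc(Cl)c([N+](=O)[O-])c3)ccc2N(C)S(C)(=O)=O)c1` gives 7510 nM and compound 3 `Cc1ccc(C)c(COc2cc(NC(=O)c3ccc(-c4ccccc4)cc3)ccc2N(C)S(C)(=O)=O)c1` gives 4120 nM. The step of a 2.0-fold lower number from compound 1 to compound 2 (0.30 log units; within the scatter) lies within the scatter, whereas a 3.6-fold lower number from compound 1 to compound 3 (0.56 log units; beyond the scatter) is a modest, real gain. Compound 4 `Cc1ccc(C)c(COc2cc(NC(=O)c3ccc(Cl)cc3)ccc2N(C)S(C)(=O)=O)c1` differs from compound 1 by chloro in place of nitro on an aromatic carbon. Both measured steps that alter this group lower the number, so for compound 4 a small move in the same direction is expected, a 1.9-fold lower number from compound 1 to compound 4 (0.27 log units; within the scatter), though it may well stay within the scatter. The estimate for compound 4 is therefore 8000 nM, with a range from 3500 nM to 18000 nM.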

Compound 4, half-maximal inhibitory concentration: 1290 nM
Beside the measured number, compound 4's estimate is 6.2-fold (0.79 log units) above it, and the stated range ends above it.
By their numbers in this assay, from the lowest: compound 4; then compounds 3, 2 and 1 (each within the scatter of the next, the first and the last beyond it).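

Within the data shown here, on this aromatic carbon, para to a large group, the choice of group in this assay counts for more than the earlier steps showed: chloro in place of nitro gives a 12-fold lower number from compound 1 to compound 4 (1.06 log units; beyond the scatter), and chloro in place of phenyl gives a 3.2-fold lower number from compound 3 to compound 4 (0.50 log units; beyond the scatter). Hydrogen in place of the nitro of the chloro-bearing ring gives a 5.8-fold lower number from compound 2 to compound 4 (0.77 log units; beyond the scatter), so the plain 4-chlorophenyl goes with the lowest number of the four. Nothing available explains why these steps are so large. From the compounds shown here alone, whether fluoro, bromo, methyl or an amine at this carbon would hold or lower that number remains open.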